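A few compounds are considered here, and "the series" means these few. Any claim that something is new, unique, unknown or untested is made for them only; others in the source may bear on it.

In an assay on isolated protein for agonist activity at Bile acid receptor (Homo sapiens), read by AlphaScreen, with a stated time of 30 min (a higher number here means that more compound is needed for the effect, a lower number that less compound is needed), compound 1 `Cc1nn(-c2ccccc2I)c2c1C(c1ccc(Oc3ccccc3)cc1)SC(C)C(=O)N2` gives 1300 nM, the lowest of the two numbers in hand, while compound 2 `COc1cc([C@H]2S[C@@H](C)C(=O)Nc3c2c(C)nn3-c2ccccc2C)ccc1Oc1ccccc1` gives 1900 nM, a difference within the scatter. Compound 3 `Cc1nn(-c2ccccc2F)c2c1C(c1ccc(Oc3ccccc3)cc1)SC(C)C(=O)N2` has not yet been measured in this assay. It differs from compound 1 by fluoro in place of iodo on an aromatic carbon. Within the data shown here, no measured pair shows this change, so its size is unknown; a step of modest size, within or just beyond the scatter, is expected, with weaker binding somewhat more likely, giving an estimated step of a 1.7-fold higher number from compound 1 to compound 3 (0.23 log units; within the scatter). Compound 3 is therefore estimated at 2200 nM, within 600 nM to 8000 nM.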

Compound 3, half-maximal effective concentration: 3900 nM
Compound 3: the middle estimate sits 1.8-fold (0.25 log units) below what was measured, within the range that was stated.
By their numbers in this assay, from the lowest: compounds 1 and 2 (each within the scatter of the next); then compound 3.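

Among these compounds, replacing iodo with fluoro at this position is not a neutral swap: going from 2-iodophenyl to 2-fluorophenyl gives a 3.0-fold higher number from compound 1 to compound 3 (0.48 log units; beyond the scatter) and is the first single-place change that can be read. At this position, the iodo compound therefore needs less compound for the effect than the fluoro compound. No measurement offered here explains the step. The compounds shown leave open how chloro, bromo or methoxy would behave at this position, and whether the same change would give a similar step on another scaffold.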